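The source may hold more compounds than are shown below. What is called first, only, known or untested is meant among the compounds shown, and "the series" means these compounds.

Working notes on the series. Compound 1 `CCc1nn(C)c(CO/N=C/c2c(C)nn(C)c2Oc2ccc(Cl)cc2)c1Cl` and compound 2 `CCc1nn(C)c(CO/N=C/c2c(C)nn(C)c2Oc2ccc(Br)cc2)c1Cl` share one core, while compound 3 `Cc1nn(C)c(Oc2ccc(Cl)cc2)c1/C=N\OCc1c(Cl)c(-c2ccc(Cl)cc2)nn1C` is built on another; the difference between the two cores is not broken down here. In a functional assay on SMMC-7721 cells (Homo sapiens) for inhibition, read by MTT assay, with a stated time of 72 h, tested at 25 uM (a lower number here means less inhibition, a higher number more inhibition at the concentration tested (going by the name of the read-out)), compound 1 gives < 80%, which is a limit of the assay and not a number. Compound 2 gives < 80% in this assay, again a limit. Among the compounds with values here, compound 3 gives 80% in this assay, the only number among the three measured compounds.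

The change from compound 1 to compound 2 is bromo in place of chloro on an aromatic carbon. Its step, a step that the two limits leave unreadable from compound 1 to compound 2, cannot be sized because the limit of < 80% in this assay, at which 2 of the 3 values shown sit, holds both of its compounds.

Compound 4 `Cc1nn(C)c(Oc2ccc(Br)cc2)c1/C=N\OCc1c(Cl)c(-c2ccc(Cl)cc2)nn1C` is still to be measured in this assay. Within the data shown here, it differs from compound 3 by bromo in place of chloro on an aromatic carbon, the same change as the one from compound 1 to compound 2, at a place described in the same words. Among the measured compounds shown here, no readable step exists for this change anywhere, and the change is small in what it counts, so the only footing is compound 3 and its value 80%. Compound 4 is therefore expected to sit near compound 3, with an expected step of a number 2 percentage points lower from compound 3 to compound 4 (within the scatter) that stays within the usual scatter. The estimate for compound 4 is 78%, expected to fall between 60% and 92%, with a real chance that this assay returns only a limit for it.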

Compound 4, a percentage reported as inhibition, at one concentration (the size of the read-out at that concentration, not a potency): 80%
For compound 4 the middle estimate is 2 percentage points below the measured one; measured number inside the range.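

Bromo in place of chloro, read here as 4-chlorophenoxy to 4-bromophenoxy, gives no change at the digits printed from compound 3 to compound 4 (within the scatter) in this assay. Whether the same change behaves alike on the core of compound 1 cannot be read, because compound 1 and compound 2 both carry a limit of the assay and not a number: the limit of < 80% in this assay, at which 2 of the 4 values shown sit. The series therefore offers one readable step on one core, which shows that the change is silent on that core in this read-out at the single concentration tested, but does not show that it is silent on the core of compound 1 or that its outcome transfers between the two cores.

The compounds shown carry only chloro and bromo at this place on the phenoxy ring, so what an amine, a carboxylic acid or a methoxy group there would give in this assay stays open. Going by these compounds, a percentage at one concentration is not a potency, so how compound 3 and compound 4 would compare across a range of concentrations also stays open.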